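Swapping pyrrolidin-1-yl for dimethylamino on compound 2

A few compounds are considered here, and "the series" means these few. Any claim that something is new, unique, unknown or untested is made for them only; others in the source may bear on it.

Among the measured compounds shown here, in an ADME assay on L6 cells (Rattus norvegicus) for cytotoxicity, with a stated time of 72 h (on this read-out higher numbers stand for weaker inhibition and lower numbers for stronger inhibition), compound 2 (`CC(C)(C)C(=O)OC1CC2(N3CCCC3)CC(c3ccccc3)C1C(c1ccccc1)C2`) gives 7620 nM and stands lowest of the two numbers so far. Compound 1 (`CN(C)C12CC(OC(=O)CN3CCCC3)C(C(c3ccccc3)C1)C(c1ccccc1)C2`) gives 32700 nM and lies above it, beyond the usual scatter. Compound 3 (`CN(C)C12CC(OC(=O)C(C)(C)C)C(C(c3ccccc3)C1)C(c1ccccc1)C2`) matches compound 2 except for one change (dimethylamino in place of pyrrolidin-1-yl on a saturated ring carbon): dimethylamino in place of pyrrolidin-1-yl on a saturated ring carbon. For the measured compounds named here, no measured pair shows this swap alone, so only a small rise in this assay is expected, probably within the scatter, with a 1.4-fold higher number from compound 2 to compound 3 (0.16 log units; within the scatter) as the estimated step. The estimate for compound 3 is 11000 nM with an expected range of 4500 nM to 30000 nM for this compound.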

Compound 3, half-maximal inhibitory concentration: 5060 nM
Compound 3: middle estimate off by 2.2-fold (0.34 log units), on the high side; the measured number falls inside the stated range.
By their numbers in this assay, from the lowest: compounds 3 and 2 (each within the scatter of the next); then compound 1.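

In this assay, dimethylamino in place of pyrrolidin-1-yl on a saturated ring carbon gives a 1.5-fold lower number from compound 2 to compound 3 (0.18 log units; within the scatter), so the two amines read alike at this position. By contrast, tert-butyl in place of (pyrrolidin-1-yl)methyl on a carbonyl carbon gives a 6.5-fold lower number from compound 1 to compound 3 (0.81 log units; beyond the scatter), showing that this assay can respond to a change at that carbonyl carbon. No measurement here explains either step. Going by these compounds, whether diethylamino or morpholin-4-yl on the same ring carbon would also match these two amines remains open. So does the effect of a hydroxyl group in place of the ((tert-butyl)carbonyl)oxy group.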